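The source may report more compounds than this note shows. Statements on the series, on what has been measured and on what is new or still open speak of the compounds shown alone.

Measured in a functional assay on MGC-803 cells (Homo sapiens) for antiproliferative activity, read by MTT assay, with a stated time of 72 h; a lower number here means a stronger inhibitor, a higher number a weaker inhibitor:
- compound 1 `CCCSc1nc(N/N=C/c2cccnc2)c2nnn(Cc3ccccc3)c2n1`: 38100 nM
- compound 2 `C#CCSc1nc(N/N=C(\C)c2ccccc2O)c2nnn(Cc3ccccc3)c2n1`: 3820 nM
- compound 3 `CCCSc1nc(N/N=C(\C)c2ccccc2O)c2nnn(Cc3ccc(Br)cc3)c2n1`: 11300 nM

In this assay compound 1 stands at the highest number of the three. Compound 3 lies nearest to it and compound 2 furthest, both gaps beyond the usual scatter. Among the measured compounds shown here, no pair of measured compounds differs in only one place, so no single change has been isolated.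

Compound 4 `CCCSc1nc(N/N=C/c2ccc([N+](=O)[O-])cc2)c2nnn(Cc3ccccc3)c2n1` is not yet measured. It differs from compound 1 as follows: 4-nitrophenyl in place of pyridin-3-yl on a carbon with a double bond to nitrogen. For the measured compounds named here, no measured pair shows this change on its own. The expectation is a small step from compound 1 to compound 4 in this assay, toward a lower number if anything, and not clearly beyond the scatter. For compound 4 the estimated value in this assay is 25000 nM, within 8000 nM to 70000 nM, which means an expected step of a 1.5-fold lower number from compound 1 to compound 4 (0.18 log units; within the scatter).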

Compound 4, half-maximal inhibitory concentration: 10100 nM
The estimate for compound 4 lay 2.5-fold (0.39 log units) above the measured number; low and high end bracket the measured number.
By their numbers in this assay, from the lowest: compound 2; then compounds 4 and 3 (each within the scatter of the next); then compound 1.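

In this assay, among the compounds shown here, 4-nitrophenyl in place of pyridin-3-yl on a carbon with a double bond to nitrogen gives a 3.8-fold lower number from compound 1 to compound 4 (0.58 log units; beyond the scatter) as the only single change isolated. This position therefore responds to the group it carries, though modestly, with the rest of compound 1 unchanged. No measurement at hand accounts for the step.

A single pair cannot separate the contribution of the nitro group from that of the carbon-only ring. Plain phenyl or 4-aminophenyl at this position would be needed to do so, and whether the step carries over to other compounds in the series remains open.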